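Trifluoromethyl for fluoro in a trifluoroalkoxy anilino series

The source may report more compounds than this note shows. Statements on the series, on what has been measured and on what is new or still open speak of the compounds shown alone.

Measured in an assay on mitochondria from L6 cells (Rattus norvegicus) for activation, with a stated time of 90 min; on this read-out higher numbers stand for an effect only at larger amounts of compound and lower numbers for an effect already at smaller amounts:
compound 1, `Oc1nc2nonc2nc1Nc1ccc(OCC(F)(F)F)c(F)c1`: 10400 nM
compound 2, `Oc1nc2nonc2nc1Nc1ccc(OCC(F)(F)F)c(C(F)(F)F)c1`: 4000 nM
compound 3, `Oc1nc2nonc2nc1Nc1ccc(OCCCC(F)(F)F)c(F)c1`: 4200 nM

Compound 3 reaches its number by way of a 2.5-fold lower number from compound 1 to compound 3 (0.39 log units; beyond the scatter). On the three numbers shown, compound 3 is set apart only from compound 1; its gap to compound 2 lies within the scatter, so the two cannot be ordered. Compound 4, `Oc1nc2nonc2nc1Nc1ccc(OCCCC(F)(F)F)c(C(F)(F)F)c1`, has not been measured in this assay. It differs from compound 3 in one place: trifluoromethyl in place of fluoro on an aromatic carbon.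

Among the measured compounds shown here, one measured step bears directly on this change, the same exchange made on compound 1: a 2.6-fold lower number from compound 1 to compound 2 (0.41 log units; beyond the scatter). Going by these compounds, that step was modest but beyond the scatter, and it stands alone; the data hold no second instance of the exchange on a 4,4,4-trifluorobutoxy partner, so whether the two changes add up is untested.

Taking the single precedent at face value, the step for compound 4 is expected to be a 2.6-fold lower number from compound 3 to compound 4 (0.42 log units; beyond the scatter), in the same direction as before. The estimated number for compound 4 in this assay is therefore 1600 nM, with a range from 700 nM to 3600 nM.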

Compound 4, half-maximal effective concentration: 2100 nM
Compound 4: middle estimate off by 1.3-fold (0.12 log units), on the low side, within the range that was stated.
By their numbers in this assay, from the lowest: compounds 4, 2 and 3 (each within the scatter of the next); then compound 1.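

Trifluoromethyl in place of fluoro on this aromatic carbon, ortho to the alkoxy group, now has a second reading on the 4,4,4-trifluorobutoxy partner, and the size of the step holds: the same change on two cores in this assay, a 2.6-fold lower number (0.41 log units; beyond the scatter) from compound 1 to compound 2 and a 2.0-fold lower number (0.30 log units; within the scatter) from compound 3 to compound 4, 1.3-fold (0.11 log units) apart, within the scatter of two such steps.

The chain change likewise has a second reading, now with trifluoromethyl on the ring, and agrees with its first: the same change on two cores in this assay, a 2.5-fold lower number (0.39 log units; beyond the scatter) from compound 1 to compound 3 and a 1.9-fold lower number (0.28 log units; within the scatter) from compound 2 to compound 4, 1.3-fold (0.11 log units) apart, within the scatter of two such steps.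

Read alone in this assay, however, neither a 2.0-fold lower number from compound 3 to compound 4 (0.30 log units; within the scatter) nor a 1.9-fold lower number from compound 2 to compound 4 (0.28 log units; within the scatter) can be separated from the scatter, so the four compounds show two changes that run in the same direction on both partners, not a firm gain from either change on its own.

The compounds shown leave open whether this parallel extends beyond fluoro and trifluoromethyl on the aromatic carbon, for instance to chloro, methyl or a nitrile. They also leave open how the chain behaves beyond these two fluorinated lengths, as with a plain butoxy chain without fluorine, a longer chain, or a chain ending in an amine or a carboxylic acid.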